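Plasma stability across three esters and one acid in the series

The source may report more compounds than this note shows. Statements on the series, on what has been measured and on what is new or still open speak of the compounds shown alone.

Compound 2 `CC(C)C(=O)OCOC(=O)C1=C(S[C@@H]2CN[C@H](C(=O)Nc3cccc(C(=O)OCOC(=O)C(C)C)c3)C2)[C@H](C)[C@@H]2[C@@H]([C@@H](C)O)C(=O)N12` gives 1% in an ADME assay on a cell-free system (plasma, Rattus norvegicus) for metabolic stability, read by LC-MS, with a stated time of 60 min, at 37 degrees C, tested at 50 uM; on this read-out lower numbers stand for a less stable compound and higher numbers for a more stable compound; this number sits within the usual scatter of compound 1 `CC(C)C(=O)OCOC(=O)C1=C(S[C@@H]2CN[C@H](C(=O)Nc3cccc(C(=O)O)c3)C2)[C@H](C)[C@@H]2[C@@H]([C@@H](C)O)C(=O)N12`, which gives 0%, and of compound 3 `CCOC(=O)C1=C(S[C@@H]2CN[C@H](C(=O)Nc3cccc(C(=O)OCC)c3)C2)[C@H](C)[C@@H]2[C@@H]([C@@H](C)O)C(=O)N12`, which gives 0%. Compound 4 `CC(C)C(=O)OCOC(=O)c1cccc(NC(=O)[C@@H]2C[C@H](SC3=C(C(=O)O)N4C(=O)[C@H]([C@@H](C)O)[C@H]4[C@H]3C)CN2)c1` is unmeasured; from compound 2 it differs by hydrogen in place of ((isopropylcarbonyl)oxy)methyl on an oxygen next to a carbonyl group. For the measured compounds named here, the only measured step of this kind, a number 1 percentage points higher from compound 1 to compound 2 (within the scatter), changed nothing beyond the scatter at the other ester site. Going by the values given here, no measured compound stands apart here, so a step of no size beyond the scatter is expected, a number 1 percentage points lower from compound 2 to compound 4 (within the scatter). Compound 4 is therefore estimated at 0%, within a range from 0% to 8%, expected because compound 1 already gives 0% with its free acid.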

Compound 4, percent of the compound remaining: 0%
Estimate against measurement, compound 4: no gap at the digits printed; measured number inside the range.
By their numbers in this assay, from the lowest: compounds 1, 3, 4 and 2 (each within the scatter of the next).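

In this assay, hydrogen in place of ((isopropylcarbonyl)oxy)methyl on this oxygen gives a number 1 percentage points lower from compound 2 to compound 4 (within the scatter). For the compounds shown here, this is the first reading at this ester site, and it matches the other site in showing no change beyond the scatter. With compound 2 at 1% and compound 4 at 0%, the step lies at the very bottom of the read-out, and no evidence shown bears on the reason.

Open, going by these compounds, is whether a carboxamide or a tert-butyl ester at this carbonyl would give a number beyond the scatter of compound 2. The percent remaining also leaves open which part of compound 2 is lost.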